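This account rests on a few compounds, and the source may have more. Where it says the series, first, only, none or still open, it means among the compounds named here.

Measured in a functional assay on HepG2 cells (Homo sapiens) for inhibition, read by MTT assay, with a stated time of 72 h; on this read-out higher numbers stand for weaker inhibition and lower numbers for stronger inhibition:

compound 1 `C=C(c1ccc(OC)c(F)c1)C1COC2(CCCC2)OO1`: 29300 nM
compound 2 `C=C(c1ccc(F)c(F)c1)C1COC2(CCCC2)OO1`: 38600 nM
compound 3 `C=C(c1ccc(F)c(F)c1)C1COC2(CCCCC2)OO1`: 28600 nM

The three measured compounds sit close together in this assay; the values of compound 1, compound 2 and compound 3 all lie within the scatter of one another, so no order among them is claimed.

One change has been made between two measured compounds: methoxy in place of fluoro on an aromatic carbon. It gave a 1.3-fold lower number from compound 2 to compound 1 (0.12 log units; within the scatter), a step that does not rise above the scatter.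

Compound 4 `C=C(c1ccc(OC)c(F)c1)C1COC2(CCCCC2)OO1` has not yet been measured. It carries the same change relative to compound 3: methoxy in place of fluoro on an aromatic carbon. The two place descriptions agree word for word, so the change is the same one. Compound 3 and compound 2 rest on different cores; the difference between the two cores is not broken down here, and their values in this assay show only that they lie within the scatter of each other.

The step from compound 3 to compound 4 is therefore expected to be small: the estimated step is a 1.2-fold lower number from compound 3 to compound 4 (0.09 log units; within the scatter), set beside a 1.3-fold lower number from compound 2 to compound 1 (0.12 log units; within the scatter) and resting on that single earlier pair. Compound 4 is expected to give 23000 nM, with a range from 10000 nM to 55000 nM, because the same change once gave a 1.3-fold lower number from compound 2 to compound 1 (0.12 log units; within the scatter). Among the compounds with values here, with only one prior instance, the width of this range is kept generous.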

Compound 4, half-maximal inhibitory concentration: 13100 nM
Estimate against measurement, compound 4: 1.8-fold (0.24 log units) above; low and high end bracket the measured number.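

Methoxy in place of fluoro on an aromatic carbon, read in this assay, gives a 2.2-fold lower number from compound 3 to compound 4 (0.34 log units; beyond the scatter), a modest step. Set beside the earlier pair, the change points the same way on both cores, and the two steps cannot be told apart in size: the same change on two cores in this assay, a 1.3-fold lower number (0.12 log units; within the scatter) from compound 2 to compound 1 and a 2.2-fold lower number (0.34 log units; beyond the scatter) from compound 3 to compound 4, 1.7-fold (0.22 log units) apart, within the scatter of two such steps So far the change carries from the core of compound 2 to the core of compound 3 in direction, with no sign that the core alters its size, but only one of the two steps rises above the scatter, and two pairs neither fix a size for the step nor show that it would hold on a further core.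

Open, on these data alone, is whether the step belongs to methoxy in particular or would also appear with a longer chain such as ethoxy, or with a hydroxy group or an amine, in the same place on either core. Also open, as far as these compounds go, is whether the step survives when the fluoro group that all four compounds keep on the aromatic ring gives way to another group, such as a nitrile.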